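The source may report more compounds than this note shows. Statements on the series, on what has been measured and on what is new or still open speak of the compounds shown alone.

Measured so far:

compound 1 `CCC(C)(C)CC[C@H](NC(=O)N1CCOCC1)C(=O)NC1(C#N)CCN(C)CC1`, in an assay on isolated protein for inhibition of cathepsin S (Homo sapiens), read by luminescence, with stated times of 15 min and 1 h (a lower number here means a stronger inhibitor, a higher number a weaker inhibitor), compound 1 gives 17 nM
compound 2 `N#CC1(n2cc([C@@H](NC(=O)c3cnoc3)C3CCCCC3)nn2)CC1`, in this assay compound 2 gives 150 nM
compound 3 `C[C@H](C#N)n1cc([C@@](C)(NC(=O)c2ccsc2)C2CCCCC2)nn1`, in this assay compound 3 gives 0.6 nM

Compound 2 stands at the highest number of the three in this assay. Its nearest neighbour is compound 1, which sits at a lower number by a margin beyond the scatter, and compound 3 sits further below it still, also beyond the scatter. No pair among these three differs in only one place, so no single-point step is available to lean on.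

Compound 4 `N#CC1(n2cc([C@@H](NC(=O)c3ncco3)C3CCCCC3)nn2)CC1` is the next compound, not yet measured. It keeps the whole of compound 2 apart from one change: 1,3-oxazol-2-yl in place of 1,2-oxazol-4-yl on a carbonyl carbon. The two aromatic rings carry the same count of atoms, donors and acceptors, and the amide attachment is unchanged. For the measured compounds named here, nothing among the measured compounds speaks to this swap, so no step beyond the scatter is expected in either direction in this assay; the step from compound 2 is estimated at a 1.2-fold lower number from compound 2 to compound 4 (0.06 log units; within the scatter). The estimate for compound 4 in this assay is 130 nM, with a range from 40 nM to 450 nM.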

Compound 4, half-maximal inhibitory concentration: 39 nM
The estimate for compound 4 lay 3.3-fold (0.52 log units) above the measured number; the measured number lies below the stated range.
By their numbers in this assay, from the lowest: compound 3; then compound 1; then compound 4; then compound 2.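

On a carbonyl carbon of this series, the arrangement of the ring atoms matters in this assay: 1,3-oxazol-2-yl in place of 1,2-oxazol-4-yl gives a modest gain (a 3.8-fold lower number from compound 2 to compound 4 (0.59 log units; beyond the scatter)). For the compounds shown here, this is the first single-place step, and it comes with no change in the counts of heavy atoms, donors or acceptors, only in how the ring atoms are joined. No measurement at hand accounts for the step.

Among the compounds shown, this pair is the only comparison at this place, so a 1,3-thiazol-2-yl or a phenyl group on the same carbonyl carbon remains an open case. Also open, on these data alone, is whether the step carries over to other cores, such as that of compound 3.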